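Fluoro in place of methoxy on the shared core

This account rests on a few compounds, and the source may have more. Where it says the series, first, only, none or still open, it means among the compounds named here.

Compound 1 `COc1cccc(NC(=O)N[C@@H]2C3CCN(CC3)[C@@H]2Cc2cccnc2)c1` has been read in an assay on a protein complex for binding affinity to Neuronal acetylcholine receptor; alpha4/beta2 (Homo sapiens); on this read-out higher numbers stand for weaker inhibition and lower numbers for stronger inhibition; for compound 1 the result is a limit, > 10000 nM, and not a number. Compound 2 `COc1ccc(NC(=O)N[C@@H]2C3CCN(CC3)[C@@H]2Cc2cccnc2)c(OC)c1` is likewise known in this assay only as a limit, > 10000 nM. Compound 1 therefore occupies no measurable position among the numbers shown, which consist only of limits: the limit of > 10000 nM in this assay, at which 2 of the 2 values shown sit. Compound 3 `O=C(Nc1cccc(F)c1)N[C@@H]1C2CCN(CC2)[C@@H]1Cc1cccnc1` has not yet been measured in this assay. It differs from compound 1 by fluoro in place of methoxy on an aromatic carbon, in words, fluoro in place of methoxy on an aromatic carbon. Among the compounds with values here, no step between measured compounds is available, so nothing measured guides the size or direction of this change. With both known values resting at the limit, the expected step is a step that the limit leaves unreadable from compound 1 to compound 3, none beyond the scatter. Compound 3 is accordingly estimated at 15000 nM, within a range from 3000 nM to 60000 nM, most probably reported once more as a limit.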

Compound 3, inhibition constant: > 10000 nM
Compound 3: only a limit was reported; the forecaster's own chance of this, stated with the estimate: 70%; the middle value is on the limit's open side.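

Compound 1 and compound 3 are both known only as limits in this assay and no step can be read between them for fluoro in place of methoxy on an aromatic carbon. The compounds shown leave open whether any change on the shared core gives a measurable value: the limit of > 10000 nM in this assay, at which 3 of the 3 values shown sit.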